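A Hydroxy Group Added to the Hydrazone Phenyl

A few compounds are considered here, and "the series" means these few. Any claim that something is new, unique, unknown or untested is made for them only; others in the source may bear on it.

compound 1 `Brc1ccc(CSc2nnc(-c3ccncc3)n2-c2ccccc2)cc1`: 12900 nM
compound 2 `O=C(CSc1nnc(-c2ccncc2)n1-c1ccccc1)N/N=C/c1ccccc1`: 18600 nM

Of the compounds shown here, two that share a core have been measured in a functional assay on HepG2 cells (Homo sapiens) for inhibition, read by MTT assay, with a stated time of 48 h; on this read-out lower numbers stand for stronger inhibition and higher numbers for weaker inhibition. In this assay compound 1 gives 12900 nM, and compound 2 gives 18600 nM. The two numbers sit within the usual scatter of each other, so compound 2 cannot be told apart from compound 1 on this evidence. Among the measured compounds shown here, the two structures differ in more than one place, so no single step connects them.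

Compound 3 `O=C(CSc1nnc(-c2ccncc2)n1-c1ccccc1)N/N=C/c1ccc(O)cc1` is not yet measured. It differs from compound 2 by hydroxy in place of hydrogen on an aromatic carbon. For the measured compounds named here, no measured pair shows such a change, so nothing in the data points in either direction. Compound 3 is therefore expected to stay close to compound 2, with an estimated step of a 1.2-fold lower number from compound 2 to compound 3 (0.09 log units; within the scatter) that does not exceed the scatter. In this assay compound 3 is estimated at 15000 nM, with a range from 5000 nM to 45000 nM.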

Compound 3, half-maximal inhibitory concentration: > 50000 nM
Compound 3 was reported as a limit; the forecaster's own chance of this, stated with the estimate: 20%; at least 3.3-fold (0.52 log units) between middle value and limit.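

In this assay the change from phenyl to 4-hydroxyphenyl gives an at least 2.6-fold higher number from compound 2 to compound 3 (0.42 log units; beyond the scatter), so this place on the ring of compound 2 is not indifferent to what it carries, something compound 1 and compound 2 alone could not show. Compound 3 is recorded as > 50000 nM, which is a limit of the assay and not a number. The step therefore sets only a floor, and the true distance between the two compounds stays unknown: the limit of > 50000 nM in this assay, at which 1 of the 3 values shown sits.

Hydroxy is the only group shown at this place, so the compounds do not tell whether the loss is particular to it or would also follow a methoxy group, an amine or a fluorine atom there. They also leave open what the same hydroxy group would do elsewhere on this ring.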